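The compounds below may be only part of what the source reports. "The series", "measured", "known", "first", "only" and "open" are said of these compounds alone.

Two compounds of this series have so far been run in a functional assay on MGC-803 cells (Homo sapiens) for cytotoxicity, read by MTT assay, with a stated time of 48 h; a lower number here means a stronger inhibitor, a higher number a weaker inhibitor. Compound 1 `CC1=NN(C(=O)CN2CCC(Cl)CC2)C(c2ccccc2O)C1` gives 30300 nM. Compound 2 `O=C(CCl)N1N=C(c2cc3ccccc3oc2=O)CC1c1ccccc1` gives 2020 nM, the lower of the two numbers, with compound 1 standing well above it, beyond the scatter. Compound 3 `CC1CCCCN1CC(=O)N1N=C(c2cc3ccccc3oc2=O)CC1c1ccccc1` is the next case; it differs from compound 2 by 2-methylpiperidin-1-yl in place of chloro on a saturated chain carbon bound to a carbonyl carbon. Among the measured compounds shown here, no step between measured compounds covers this kind of change, so only a rough expectation is possible. Compound 3 is expected to come out weaker than compound 2, by a step of a 3.0-fold higher number from compound 2 to compound 3 (0.47 log units; beyond the scatter). The estimate for compound 3 in this assay is 6000 nM, within a range of 1500 nM to 25000 nM.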

Compound 3, half-maximal inhibitory concentration: "not active" (no number reported)
For compound 3 the study gives words and no number; there is nothing to compare the estimate with.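

Among the compounds shown here, compound 3 is reported in this assay only in words, so no step from compound 2 to compound 3 can be read. The compounds shown leave open how far 2-methylpiperidin-1-yl in place of chloro shifts the number. No supporting measurement bears on this result.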